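Carboxylic acid side chain swap across two cores

A few compounds are considered here, and "the series" means these few. Any claim that something is new, unique, unknown or untested is made for them only; others in the source may bear on it.

Working notes on the series. Compound 1 `O=C(O)COc1ccc(NCc2cccc(Oc3ccccc3)c2)cc1` and compound 3 `CC(Cc1ccc(NCc2cccc(Oc3ccccc3)c2)cc1)C(=O)O` share one core; compound 2 `Cc1nc(-c2ccc(C(F)(F)F)cc2)sc1CNc1ccc(OCC(=O)O)cc1` and the unmeasured compound 4 `Cc1nc(-c2ccc(C(F)(F)F)cc2)sc1CNc1ccc(CC(C)C(=O)O)cc1` share another. The difference between the two cores is not broken down here.

In a functional assay on CHO cells for agonist activity at Free fatty acid receptor 1 (Homo sapiens) (a lower number here means that less compound is needed, a higher number that more compound is needed for the effect), compound 1 gives 2040 nM. Compound 3 differs from compound 1 by 2-carboxypropyl in place of carboxymethoxy on an aromatic carbon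
and, in this assay, compound 3 gives 100 nM, so that the step is a 20-fold lower number from compound 1 to compound 3 (1.31 log units; beyond the scatter).

On the second core, compound 2 gives 288 nM in this assay. It sits between the other two measured numbers: compound 3 is lower, compound 1 higher, both gaps beyond the scatter.

Compound 4 differs from compound 2 by 2-carboxypropyl in place of carboxymethoxy on an aromatic carbon
The place description is the same word for word as for the pair of compound 1 and compound 3, so this is the same change made on a different core. Among the measured compounds shown here, it is seen only once so far, so its size on the second core is not established; the expectation for compound 4 is therefore set a little short of the single earlier step, because the earlier step of a 20-fold lower number from compound 1 to compound 3 (1.31 log units; beyond the scatter) is large and may not carry over in full. The step from compound 2 to compound 4 in this assay is expected to be a 12-fold lower number from compound 2 to compound 4 (1.06 log units; beyond the scatter). For compound 4 the estimate in this assay is 25 nM, with the likely range from 8 nM to 80 nM.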

Compound 4, half-maximal effective concentration: 355 nM
Beside the measured number, compound 4's estimate is 14-fold (1.15 log units) below it, and the stated range ends below it.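

In this assay, 2-carboxypropyl in place of carboxymethoxy on the core of compound 2 gives a 1.2-fold higher number from compound 2 to compound 4 (0.09 log units; within the scatter), so on this core the two side chains cannot be told apart. The change therefore does not behave as a portable step in this series, as its effect depends on the core that carries it: the same change on two cores in this assay, a 20-fold lower number (1.31 log units; beyond the scatter) from compound 1 to compound 3 and a 1.2-fold higher number (0.09 log units; within the scatter) from compound 2 to compound 4, 25-fold (1.40 log units) apart, beyond the scatter of two such steps

This does not show which feature of the two cores sets the gap, and with one pair on each core it gives no general rule for a further core. It also does not show that either side chain is better in general, and only the core of compound 1 shows a step beyond the scatter.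

The compounds shown leave open whether the large step on the core of compound 1 comes with the whole 2-carboxypropyl group or with a part of it, which a 2-carboxyethyl chain without the methyl branch could help to separate on both cores. They also leave open where along the path from one core to the other the step is lost, which could be probed with cores that differ in one place only, such as the core of compound 2 with hydrogen in place of trifluoromethyl.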